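Benzyl Substituents on a Weak Monoamine Oxidase A Series

The source may hold more compounds than are shown below. What is called first, only, known or untested is meant among the compounds shown, and "the series" means these compounds.

Measured compounds:
Compound 1, `CC(C)(C)c1cc(/C=C/C(=O)NCCC2CCN(Cc3ccccc3)CC2)cc(C(C)(C)C)c1O`: 62300 nM
Compound 2, `Cc1ccccc1CN1CCC(CCNC(=O)/C=C/c2cc(C(C)(C)C)c(O)c(C(C)(C)C)c2)CC1`: 69300 nM
Compound 3, `Cc1ccc(CN2CCC(CCNC(=O)/C=C/c3cc(C(C)(C)C)c(O)c(C(C)(C)C)c3)CC2)cc1`: 70100 nM

In an assay on isolated protein for inhibition of Amine oxidase [flavin-containing] A (Homo sapiens), read by fluorescence, with stated times of 15 min and 20 min (a lower number here means a stronger inhibitor, a higher number a weaker inhibitor), compound 3 gives 70100 nM, the highest of the three numbers, yet its separation from compound 2 and compound 1 lies within the scatter. Compound 4, `CC(C)(C)c1cc(/C=C/C(=O)NCCC2CCN(Cc3ccccc3F)CC2)cc(C(C)(C)C)c1O`, is not yet measured; it differs from compound 3 by 2-fluorophenyl in place of 4-methylphenyl on a saturated chain carbon bound to an amine nitrogen in a ring. Going by the values given here, two measured steps bear on this: a 1.1-fold higher number from compound 1 to compound 2 (0.05 log units; within the scatter) and a 1.1-fold higher number from compound 1 to compound 3 (0.05 log units; within the scatter), and a 1.0-fold higher number from compound 2 to compound 3 (0.00 log units; within the scatter) shows no separation either. Changes on this phenyl ring have so far left this assay unmoved, so compound 4 is expected to give a number close to compound 3, with a 1.1-fold lower number from compound 3 to compound 4 (0.03 log units; within the scatter) anticipated to stay within the scatter. The estimate for compound 4 in this assay is 65000 nM, with a range from 30000 nM to 140000 nM.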

Compound 4, half-maximal inhibitory concentration: 60200 nM
Beside the measured number, compound 4's estimate is 1.1-fold (0.03 log units) above it, within the range that was stated.
By their numbers in this assay, from the lowest: compounds 4, 1, 2 and 3 (each within the scatter of the next).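

In this assay the 2-fluorobenzyl group of compound 4 does not separate from the benzyl groups already measured: a 1.2-fold lower number from compound 3 to compound 4 (0.07 log units; within the scatter) and a 1.2-fold lower number from compound 2 to compound 4 (0.06 log units; within the scatter) and a 1.0-fold lower number from compound 1 to compound 4 (0.01 log units; within the scatter) all lie within the scatter. The flat picture at this phenyl ring therefore extends from methyl to fluoro, a different kind of substituent. No measurement offered here accounts for this flatness. Still open, from the compounds shown here alone, is whether a carboxylic acid or an amine on this phenyl ring, or a longer chain in place of the benzyl carbon, would move the number at all.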